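The source may report more compounds than this note shows. Statements on the series, on what has been measured and on what is new or still open speak of the compounds shown alone.

Measured so far: compound 1 `CC(C(=O)NCc1ccc(C(F)(F)F)nc1Nc1ccccc1)c1ccc(NS(C)(=O)=O)c(F)c1`, 59.6 nM; compound 2 `CC(C(=O)NCc1ccc(C(F)(F)F)nc1NCc1cccnc1)c1ccc(NS(C)(=O)=O)c(F)c1`, "not active" (no number reported).

Within the data shown here, in a functional assay on CHO-K1 cells for antagonist activity at transient receptor potential cation channel subfamily V member 1 (Homo sapiens), read by FLIPR (on this read-out higher numbers stand for weaker inhibition and lower numbers for stronger inhibition), compound 1 gives 59.6 nM, the only number reported, while compound 2 is reported in this assay as "not active" (no number reported) with no number. Compound 3 `CC(C(=O)NCc1ccc(C(F)(F)F)nc1N1CCC(c2ccccc2)CC1)c1ccc(NS(C)(=O)=O)c(F)c1` has not been measured. It differs from compound 1 by 4-phenylpiperidin-1-yl in place of anilino on an aromatic carbon. Compound 2 shows that a change at this position can abolish activity, so for compound 3 the estimated step of a 6.7-fold higher number from compound 1 to compound 3 (0.83 log units; beyond the scatter) is toward weaker inhibition, beyond the scatter. Compound 3 is expected to give about 400 nM, within 60 nM to 3000 nM.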

Compound 3, inhibition constant: 0.6 nM
For compound 3 the middle estimate is 670-fold (2.82 log units) above the measured one; the measured number lies below the stated range.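

In this assay the change to 4-phenylpiperidin-1-yl in place of anilino gives a large gain in inhibition (a 99-fold lower number from compound 1 to compound 3 (2.00 log units; beyond the scatter)), so this position, where compound 2 had shown that activity can be lost, can also raise it strongly. Compound 3 has no hydrogen-bond donor in this group, so that donor of anilino is not required for strong inhibition. Nothing given here accounts for the gain. The compounds shown leave open whether a plain piperidin-1-yl, without the phenyl ring, would keep this gain. As far as these compounds go, how a morpholine or a 4-benzylpiperidine in this place would compare also stays open.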